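Cytotoxicity limits across the series; outlook for compound 4

This account rests on a few compounds, and the source may have more. Where it says the series, first, only, none or still open, it means among the compounds named here.

Compound 3 `Cc1cc(NC(=O)Nc2ccc(F)cc2)c2ccccc2n1` is the reference point here. In an ADME assay on HEK293 cells (Homo sapiens) for cytotoxicity, with a stated time of 72 h (on this read-out lower numbers stand for an effect already at smaller amounts and higher numbers for an effect only at larger amounts of compound), compound 3 gives > 25000 nM, which is a limit of the assay and not a number. Compound 1 `Cc1cc(NC(=O)Nc2ccc(C(=O)O)cc2)c2ccccc2n1` gives in this assay the value > 25000 nM, again a limit. Compound 2 `Cc1cc(NC(=O)Nc2ccccc2F)c2ccccc2n1` gives in this assay the value > 25000 nM, also a limit. Among the compounds with values here, the steps that bear on the change are a step that the two limits leave unreadable from compound 1 to compound 3 and a step that the two limits leave unreadable from compound 2 to compound 3; neither can be sized, since (the limit of > 25000 nM in this assay, at which 3 of the 3 values shown sit). Compound 4 `CSc1ccc(NC(=O)Nc2cc(C)nc3ccccc23)cc1` differs from compound 3 by methylsulfanyl in place of fluoro on an aromatic carbon. With every value of the series sitting at one limit, no step beyond the scatter in either direction is expected, and the expected step is a step that the limit leaves unreadable from compound 3 to compound 4. For compound 4 in this assay the estimate is 30000 nM, with a range from 8000 nM to 100000 nM, and a limit rather than a number is again likely.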

Compound 4, half-maximal effective concentration: 24000 nM
Compound 4: the middle estimate sits 1.3-fold (0.10 log units) above what was measured, and the stated range covers the measured number.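

Within the data shown here, with methylsulfanyl in place of fluoro on this aromatic carbon, this assay yields the first number of the series rather than a limit, with an at least 1.0-fold lower number from compound 3 to compound 4 (0.01 log units; that floor lies within the scatter). Methylsulfanyl in place of carboxy gives the same reading, with an at least 1.0-fold lower number from compound 1 to compound 4 (0.01 log units; that floor lies within the scatter). Neither step can be called a real change, and the steps among the other compounds cannot be read, as the remaining values are limits: the limit of > 25000 nM in this assay, at which 3 of the 4 values shown sit.

Still open, from the compounds shown here alone, is the true size of both steps. Also open, going by these compounds, is whether an amine or a longer chain on this aromatic carbon would give a number beyond the scatter.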